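Two Growth Inhibition Values and an Unmeasured Pyrrolidine Analogue

This account rests on a few compounds, and the source may have more. Where it says the series, first, only, none or still open, it means among the compounds named here.

- Compound 1 `Cc1cc(=O)c2c(O)cc(OCc3ccc(Br)cc3)c([C@H]3CCN(C)C[C@H]3O)c2o1` gives 13%
- Compound 2 `CCN(CC)Cc1c(O)c([C@H]2CCN(C)C[C@H]2O)c2oc(C)cc(=O)c2c1O` gives 27%

In a functional assay on MIA PaCa-2 cells (Homo sapiens) for inhibition, read by MTT assay, with a stated time of 48 h, tested at 10 uM (a lower number here means less inhibition of growth, a higher number more inhibition of growth at the concentration tested), compound 2 stands highest of the two measured, with 27% against the lower compound 1. Compound 3 `Cc1cc(=O)c2c(O)c(CN3CC(O)CC3C(=O)O)c(O)c([C@H]3CCN(C)C[C@H]3O)c2o1` has not yet been measured. It differs from compound 2 by 2-carboxy-4-hydroxypyrrolidin-1-yl in place of diethylamino on a saturated chain carbon bound to an aromatic carbon with 2-carboxy-4-hydroxypyrrolidin-1-yl in place of diethylamino on a saturated chain carbon bound to an aromatic carbon. Within the data shown here, no measured pair shows this change. A moderate fall is expected, with the estimated a number 12 percentage points lower from compound 2 to compound 3 (beyond the scatter) lying little beyond the scatter. For compound 3 the estimated value is 15% within a range of 3% to 32%.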

Compound 3, percent growth inhibition at one concentration: 23%
Estimate against measurement, compound 3: 8 percentage points below, within the range that was stated.
By their numbers in this assay, from the lowest: compounds 1, 3 and 2 (each within the scatter of the next, the first and the last beyond it).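

In this assay, among these compounds, the first comparison of compounds differing in one place puts 2-carboxy-4-hydroxypyrrolidin-1-yl in place of diethylamino on a saturated chain carbon bound to an aromatic carbon, and the step reads a number 4 percentage points lower from compound 2 to compound 3 (within the scatter). At this position, then, the larger ring-bearing group with its added hydrogen-bond donors and acceptors leaves the growth inhibition indistinguishable from that of diethylamino. No measurement here accounts for this result. The compounds shown leave open how a plain pyrrolidin-1-yl or a morpholin-4-yl would read at this position, and so whether the carboxylic acid or the hydroxyl of the entering group matters.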